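The compounds below may be only part of what the source reports. "The series", "measured", "known", "first", "only" and "open" are said of these compounds alone.

Measured so far in a functional assay on PC-3 cells (Homo sapiens) for cytotoxicity, read by MTT assay, with a stated time of 96 h; a higher number here means a weaker inhibitor, a lower number a stronger inhibitor:
Compound 1 `Cc1ccc(NCc2cnc3cc([N+](=O)[O-])ccc3n2)cc1` — 57000 nM
Compound 2 `Cc1cccc(NCc2cnc3cc([N+](=O)[O-])ccc3n2)c1` — 77000 nM

Compound 1 has the lowest of these two numbers, but the gap to compound 2, a 1.4-fold higher number from compound 1 to compound 2 (0.13 log units; within the scatter), lies within the scatter, so the two compounds cannot be placed in order. The new compound 3 `O=C(O)c1ccc(NCc2cnc3cc([N+](=O)[O-])ccc3n2)cc1` differs from compound 1 by carboxy in place of methyl on an aromatic carbon. Within the data shown here, the only measured step, from compound 1 to compound 2, exchanges one methylphenyl for another rather than replacing the methyl with a different group, so it bears only loosely on this change; it shows that a small change on this ring left the number about where it was. Among the measured compounds shown here, no measured step covers carboxy in place of methyl. The step of a 1.4-fold higher number from compound 1 to compound 3 (0.15 log units; within the scatter) is therefore expected to be small, in either direction, with a wide range of uncertainty. Compound 3 is estimated at 80000 nM, within 30000 nM to 250000 nM.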

Compound 3, half-maximal inhibitory concentration: 45000 nM
For compound 3 the middle estimate is 1.8-fold (0.25 log units) above the measured one, and the stated range covers the measured number.
By their numbers in this assay, from the lowest: compounds 3, 1 and 2 (each within the scatter of the next).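

In this assay, carboxy in place of methyl on an aromatic carbon, para to a large group, gives a 1.3-fold lower number from compound 1 to compound 3 (0.10 log units; within the scatter), so the two numbers cannot be told apart. The earlier pair only moved a methyl around the ring, whereas this result replaces the methyl with a different kind of group, one that brings oxygen atoms and a hydrogen-bond donor and acceptor, and the number still stays within the scatter. No measurement at hand offers an explanation for this result.

As far as these compounds go, whether an amine or a longer carbon chain at this same place would give a step beyond the scatter remains open. Also open, from the compounds shown here alone, is what carboxy would do at the place the methyl holds in compound 2.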